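A tert-Butyl Urea in Place of the Acetyl Group

This account rests on a few compounds, and the source may have more. Where it says the series, first, only, none or still open, it means among the compounds named here.

Compound 1 `O=C(CN1CCNCC1)N1CCC(NS(=O)(=O)c2cc(S(=O)(=O)c3ccccc3)ccc2C(F)(F)F)CC1` gives 250 nM in a functional assay on U2OS cells for antagonist activity at proto-oncogene Wnt-3 (Homo sapiens), read by a luciferase reporter, with a stated time of 18 h; a higher number here means that more compound is needed for the effect, a lower number that less compound is needed. Compound 2 `CC(C)(C)OC(=O)N1C(=O)CC[C@H]1C(=O)N1CCC(NS(=O)(=O)c2cc(S(=O)(=O)c3ccccc3)ccc2C(F)(F)F)CC1` gives 90 nM. Compound 3 `CC(=O)N1CCC[C@H]1C(=O)N1CCC(NS(=O)(=O)c2cc(S(=O)(=O)c3ccccc3)ccc2C(F)(F)F)CC1` gives 250 nM.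

Compound 3 stands level with compound 1 at the digits measured, and these two together hold the highest numbers of the three in this assay; compound 2 sits at a lower number than compound 3, beyond the scatter. Compound 4 `CC(C)(C)NC(=O)N1CCC[C@H]1C(=O)N1CCC(NS(=O)(=O)c2cc(S(=O)(=O)c3ccccc3)ccc2C(F)(F)F)CC1` differs from compound 3 by (tert-butyl)amino in place of methyl on a carbonyl carbon. Within the data shown here, only one measured step touches this part of the molecule: no change at the digits printed from compound 1 to compound 3 (within the scatter), which swapped the whole group on the carbonyl carbon without moving the number. A further hint comes from compound 2, whose tert-butyl-bearing group on the ring nitrogen gives a lower number than compound 3, but that pair differs in more than one place. A small downward step, if any, is therefore expected. Compound 4 is estimated at 160 nM, within 60 nM to 400 nM, a step of a 1.6-fold lower number from compound 3 to compound 4 (0.19 log units; within the scatter) that is expected to stay near the scatter.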

Compound 4, half-maximal effective concentration: 30 nM
For compound 4 the middle estimate is 5.3-fold (0.73 log units) above the measured one, and the stated range ends above it.
By their numbers in this assay, from the lowest: compound 4; then compound 2; then compounds 1 and 3 (each within the scatter of the next).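

In this assay, going from acetyl to (tert-butyl)carbamoyl gives an 8.3-fold lower number from compound 3 to compound 4 (0.92 log units; beyond the scatter), so the group on this carbonyl carbon can move the number, which the earlier step of no change at the digits printed from compound 1 to compound 3 (within the scatter) had not shown. Against the (piperazin-1-yl)methyl group, the step is the same: an 8.3-fold lower number from compound 1 to compound 4 (0.92 log units; beyond the scatter). Nothing available here explains this drop. The compounds shown leave open which part of the (tert-butyl)amino group carries the step, the nitrogen or the tert-butyl. A methylamino group or a tert-butyl attached directly to this carbonyl carbon would separate the two.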